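Replacing 4-methylphenyl by methyl in compound 1

A few compounds are considered here, and "the series" means these few. Any claim that something is new, unique, unknown or untested is made for them only; others in the source may bear on it.

compound 1 `Cc1ccc(C(=O)Nc2nnc(-c3ccc(O)c(O)c3)s2)cc1` gives 34000 nM
compound 2 `CC(=O)Nc1nnc(-c2cccc(O)c2O)s1` gives 111000 nM
compound 3 `Cc1ccc(C(=O)Nc2nnc(-c3cccc(O)c3O)s2)cc1` gives 27100 nM

In a functional assay, with a stated time of 30 min, in the absence of a further agent (on this read-out lower numbers stand for stronger inhibition and higher numbers for weaker inhibition), compound 1 gives 34000 nM as its value. Compound 3 gives 27100 nM as its value. The gap between compound 1 and compound 3 lies within the scatter. Compound 2 gives 111000 nM as its value. The gap between compound 1 and compound 2 lies beyond the scatter, with compound 1 on the lower side.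

Not yet measured is compound 4 `CC(=O)Nc1nnc(-c2ccc(O)c(O)c2)s1`, which carries methyl in place of 4-methylphenyl on a carbonyl carbon. Going by the values given here, the counted difference is methyl in place of 4-methylphenyl on a carbonyl carbon as the only change.

Among the compounds with values here, one measured step bears on this exchange, and it runs in the opposite sense: a 4.1-fold lower number from compound 2 to compound 3 (0.61 log units; beyond the scatter) as the size. It was measured on a core that is not the core of compound 1, so its transfer is uncertain. Read in reverse, it points to a higher number in this assay of similar modest size, beyond the scatter. The expected step is a 3.5-fold higher number from compound 1 to compound 4 (0.55 log units; beyond the scatter) as an estimate. For compound 4 the estimated value is 120000 nM with an expected range from 50000 nM to 280000 nM as its ends.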

Compound 4, half-maximal inhibitory concentration: 23400 nM
For compound 4 the middle estimate is 5.1-fold (0.71 log units) above the measured one; measured number below the stated range.
By their numbers in this assay, from the lowest: compounds 4, 3 and 1 (each within the scatter of the next); then compound 2.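

In this assay, methyl and 4-methylphenyl on the carbonyl carbon cannot be told apart on the core of compound 1: a 1.5-fold lower number from compound 1 to compound 4 (0.16 log units; within the scatter). The 4-methylphenyl group therefore shows no general advantage at this position, and the phenol pattern of the core decides whether the exchange registers at all. The two matched pairs do not agree, so a step read on one core cannot be carried over to the other: the same change on two cores in this assay, a 4.1-fold lower number (0.61 log units; beyond the scatter) from compound 2 to compound 3 and a 1.5-fold higher number (0.16 log units; within the scatter) from compound 4 to compound 1, 6.0-fold (0.77 log units) apart, beyond the scatter of two such steps.

From the compounds shown here alone, whether a longer chain or an amine on this carbonyl carbon would separate from methyl and 4-methylphenyl on either core remains open. The two pairs also give no reason for the disagreement, and they cannot show whether it would hold for further substituents at this position.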